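Removing the Fluoro Substituent from Compound 1

The source may report more compounds than this note shows. Statements on the series, on what has been measured and on what is new or still open speak of the compounds shown alone.

Compound 1 `COc1ccc(N/C=C\C(=O)c2nc(-c3ccc(F)cc3)n3ccccc23)cc1` gives 15700 nM in a functional assay on BT-474 cells (Homo sapiens) for cytotoxicity, read by MTT assay, with a stated time of 48 h; on this read-out lower numbers stand for stronger inhibition and higher numbers for weaker inhibition.
Compound 2 `COc1ccc(N/C=C\C(=O)c2nc(-c3ccc(F)cc3)n3ccccc23)cc1OC` reaches only the limit of > 30000 nM in this assay.
Compound 3 `O=C(/C=C\Nc1ccc(Cl)cc1)c1nc(-c2ccc(F)cc2)n2ccccc12` gives 7030 nM in this assay.

Among the two numbers actually measured, compound 1 has the higher one, with compound 3 nearest at a 2.2-fold lower number from compound 1 to compound 3 (0.35 log units; beyond the scatter); compound 2 contributes only a limit, (the limit of > 30000 nM in this assay, at which 1 of the 3 values shown sits). The measured steps all concern the aniline part: an at least 1.9-fold higher number from compound 1 to compound 2 (0.28 log units; that floor lies within the scatter), a 2.2-fold lower number from compound 1 to compound 3 (0.35 log units; beyond the scatter) and an at least 4.2-fold lower number from compound 2 to compound 3 (0.63 log units; beyond the scatter).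

Compound 4 `COc1ccc(N/C=C\C(=O)c2nc(-c3ccccc3)n3ccccc23)cc1` differs from compound 1 elsewhere: hydrogen in place of fluoro on an aromatic carbon. Going by the values given here, none of the measured steps touches this ring, so no measured step bears on it, and the change itself removes only a single small atom. In this assay, on these data alone, a step from compound 1 to compound 4 of no size beyond the scatter is therefore expected, with a slight lean toward a higher number, as the fluorophenyl ring is shared by all three measured compounds and its contribution is unknown. The expected step is a 1.1-fold higher number from compound 1 to compound 4 (0.06 log units; within the scatter). For compound 4 the estimate in this assay is 18000 nM, between 8000 nM and 40000 nM.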

Compound 4, half-maximal inhibitory concentration: 12800 nM
Estimate against measurement, compound 4: 1.4-fold (0.15 log units) above; the range from low to high includes it.
By their numbers in this assay, from the lowest: compounds 3, 4 and 1 (each within the scatter of the next, the first and the last beyond it). At a limit, above all of these: compound 2.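

In this assay, the change from 4-fluorophenyl to phenyl amounts to a 1.2-fold lower number from compound 1 to compound 4 (0.09 log units; within the scatter). Going by these compounds alone, this is the first reading on the ring that all the earlier compounds share, and it shows that the fluoro, para to a large group, can be replaced by hydrogen with no difference this read-out can separate from the scatter, at least with the aniline part of compound 1. Nothing available here bears on why the two compounds read alike, so the result stands as an observation about this one pair.

Within the data shown here, whether hydrogen in place of fluoro would read the same way on the background of compound 3, with its 4-chlorophenyl on the amine nitrogen, stays open, since the only pair on this ring has the aniline part of compound 1. Also open is how this position would respond to a group of a different kind in place of the fluoro, such as an amine, a carboxylic acid or a morpholine, since the compounds shown carry only fluoro or hydrogen there.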